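Compound 1 to compound 4: furan-2-yl replaced

This account rests on a few compounds, and the source may have more. Where it says the series, first, only, none or still open, it means among the compounds named here.

Values in an ADME assay on S9 fraction from liver (Rattus norvegicus) for metabolic stability, read by LC-MS, using NADPH, with a stated time of 90 min, tested at 5 uM (a higher number here means that more of the compound is left, a lower number that less of the compound is left), are as follows.
- compound 1 (`O=C(NO)c1cc(F)c(Cn2nnc(-c3ccco3)n2)c(F)c1`) gives 68%
- compound 2 (`Cn1c(Sc2c(F)cc(C(=O)NO)cc2F)nnc1-c1cccnn1`) gives 58%
- compound 3 (`Cn1c(Sc2c(F)cc(C(=O)NO)cc2F)nnc1-c1cccc(CN2CCCCCC2)c1`) gives 55%

Compound 1 carries the highest of the three numbers, within the scatter of compound 2 and beyond it only against compound 3. Compound 4 (`Nc1ccc(-c2nnn(Cc3c(F)cc(C(=O)NO)cc3F)n2)cc1`) has 4-aminophenyl in place of furan-2-yl on an aromatic carbon. Within the data shown here, no measured pair differs in one place, so this assay shows no direct precedent for this change. Among the measured compounds shown here, the only guide is the narrow spread of the three values, with compound 3 at (55%). A modest downward step is therefore expected (a number 13 percentage points lower from compound 1 to compound 4 (beyond the scatter)). Compound 4 is estimated at 55% (range 35% to 72%).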

Compound 4, percent of the compound remaining: 48%
Compound 4: the middle estimate sits 7 percentage points above what was measured; the measured number falls inside the stated range.
By their numbers in this assay, from the lowest: compounds 4, 3, 2 and 1 (each within the scatter of the next, the first and the last beyond it).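

In this assay, the aromatic carbon bearing furan-2-yl gives its first direct reading: 4-aminophenyl in place of furan-2-yl gives a number 20 percentage points lower from compound 1 to compound 4 (beyond the scatter). Among these compounds, this position therefore responds to a change of group, though only this single pair supports that reading. Nothing available accounts for the step. As far as these compounds go, it remains open whether the amine or the six-membered aromatic ring of carbon only goes with the lower number. Plain phenyl at this carbon would separate the two, and a carboxylic acid in place of the amine would test that end of the group.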